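The source may hold more compounds than are shown below. What is called first, only, known or untested is meant among the compounds shown, and "the series" means these compounds.

Series notes. In a functional assay on A549 cells (Homo sapiens) for antiproliferative activity, read by MTT assay, with a stated time of 24 h (on this read-out lower numbers stand for stronger inhibition and higher numbers for weaker inhibition), compound 1 `O=c1[nH]cc(S(=O)(=O)Nc2ccccc2-c2cn(-c3ccccc3)nn2)c(=O)[nH]1` gives 6790 nM. Compound 2 `O=c1[nH]cc(S(=O)(=O)Nc2ccccc2-c2cn(-c3cccc(Cl)c3)nn2)c(=O)[nH]1` gives 2340 nM. Compound 3 `O=c1[nH]cc(S(=O)(=O)Nc2ccc(-c3cn(-c4ccccc4)nn3)cc2)c(=O)[nH]1` gives 7170 nM; its gap to compound 1 lies within the scatter, while its gap to compound 2 lies beyond it. Compound 4 `O=c1[nH]cc(S(=O)(=O)Nc2ccc(-c3cn(-c4cccc(F)c4)nn3)cc2)c(=O)[nH]1` is the next member, differing from compound 3 by fluoro in place of hydrogen on an aromatic carbon. Within the data shown here, the only measured step of a related kind is a 2.9-fold lower number from compound 1 to compound 2 (0.46 log units; beyond the scatter), likewise an exchange of one hydrogen for a halogen, though made on compound 1 rather than compound 3 and with chloro rather than fluoro. By analogy a modest lowering is expected, and the expected step is a 1.8-fold lower number from compound 3 to compound 4 (0.25 log units; within the scatter). Compound 4 is therefore estimated at about 4000 nM, with a range from 2000 nM to 8000 nM.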

Compound 4, half-maximal inhibitory concentration: 9980 nM
For compound 4 the middle estimate is 2.5-fold (0.40 log units) below the measured one, and the stated range ends below it.
By their numbers in this assay, from the lowest: compound 2; then compounds 1, 3 and 4 (each within the scatter of the next).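

In this assay the step of a 1.4-fold higher number from compound 3 to compound 4 (0.14 log units; within the scatter) shows that fluoro on this aromatic carbon of compound 3 leaves the number within the scatter. The lowering of a 2.9-fold lower number from compound 1 to compound 2 (0.46 log units; beyond the scatter) therefore does not reappear here, in a pair that has a different parent and a different halogen. No measurement at hand bears on this result.

Going by these compounds, whether chloro, an amine or a carboxylic acid in this place on compound 3 would move the number beyond the scatter stays open.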